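The source may hold more compounds than are shown below. What is called first, only, known or untested is meant among the compounds shown, and "the series" means these compounds.

Of the compounds shown here, three on one shared core have been measured in a functional assay on BXPC-3 cells (Homo sapiens) for antiproliferative activity, read by MTT assay, with a stated time of 24 h; on this read-out higher numbers stand for weaker inhibition and lower numbers for stronger inhibition. There compound 1 `CCn1c(C(=O)N[C@@H](C)CO)ccc1C(CC)(CC)c1ccc(OCS(=O)(=O)c2ccccc2)c(C)c1` gives 15300 nM, compound 2 `CCn1c(C(=O)N[C@H](C)CO)ccc1C(CC)(CC)c1ccc(OCS(=O)(=O)c2ccccc2)c(C)c1` gives 10000 nM, and compound 3 `CCn1c(C(=O)N[C@H](CO)CCO)ccc1C(CC)(CC)c1ccc(OCS(=O)(=O)c2ccccc2)c(C)c1` gives 15900 nM. Compound 3 therefore stands level with the other two, with a 1.0-fold higher number from compound 1 to compound 3 (0.02 log units; within the scatter) and a 1.6-fold higher number from compound 2 to compound 3 (0.20 log units; within the scatter).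

The next compound, compound 4 `CCn1c(C(=O)N[C@H](C(=O)O)C(C)C)ccc1C(CC)(CC)c1ccc(OCS(=O)(=O)c2ccccc2)c(C)c1`, changes the group on the amide-type nitrogen: 1-carboxy-2-methylpropyl in place of 3-hydroxy-1-(hydroxymethyl)propyl on an amide-type nitrogen. In words, 1-carboxy-2-methylpropyl takes the place of 3-hydroxy-1-(hydroxymethyl)propyl. The measured steps that bear on this change all sit at that same nitrogen. Swapping the configuration of the chain stereocentre gave a 1.5-fold lower number from compound 1 to compound 2 (0.18 log units; within the scatter), and exchanging 1-(hydroxymethyl)ethyl for 3-hydroxy-1-(hydroxymethyl)propyl gave a 1.6-fold higher number from compound 2 to compound 3 (0.20 log units; within the scatter). Neither step introduces a carboxy group, so they offer only an indirect guide and the range has to be kept wide. With every measured change at this nitrogen confined to the scatter, as in a 1.0-fold higher number from compound 1 to compound 3 (0.02 log units; within the scatter), no step beyond the scatter is expected in this assay, in either direction. The estimated change is a 1.1-fold lower number from compound 3 to compound 4 (0.03 log units; within the scatter). Compound 4 is expected at 15000 nM, with an estimated range from 6000 nM to 38000 nM.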

Compound 4, half-maximal inhibitory concentration: 16200 nM
Compound 4: the middle estimate sits 1.1-fold (0.03 log units) below what was measured, and the stated range covers the measured number.
By their numbers in this assay, from the lowest: compounds 2, 1, 3 and 4 (each within the scatter of the next).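

In this assay, for the compounds shown here, 1-carboxy-2-methylpropyl is the first group on the amide-type nitrogen to bear a carboxy group, and it brings no hydroxymethyl group, yet compound 4 stands level with all three earlier compounds: a 1.0-fold higher number from compound 3 to compound 4 (0.01 log units; within the scatter), a 1.6-fold higher number from compound 2 to compound 4 (0.21 log units; within the scatter) and a 1.1-fold higher number from compound 1 to compound 4 (0.02 log units; within the scatter). The earlier compounds shown here showed this only for groups bearing hydroxyl, so the level numbers now extend across hydroxyl-bearing and carboxy-bearing groups on this nitrogen, though only for these four compounds and only in this assay. Nothing given here accounts for why such different groups give level numbers.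

The compounds shown leave open whether a methyl ester in place of the carboxy group, a primary amine, a phenyl ring or a longer chain on this nitrogen would give a step beyond the scatter. They also leave open whether the opposite configuration of 1-carboxy-2-methylpropyl would stand level with compound 4, and whether any group at this position would lead to a number clearly apart from those of compounds 1 to 4.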